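Phenyl for propyl on an aminopyrimidine: tolerance expected to hold

The compounds below may be only part of what the source reports. "The series", "measured", "known", "first", "only" and "open" are said of these compounds alone.

Measured so far:
compound 1, `Nc1nc(Cl)c(-c2cccs2)c(N[C@@H]2C[C@H](CO)[C@@H](O)[C@H]2O)n1`: > 25000 nM
compound 2, `CCCNc1nc(C)c(-c2nc3ccccc3s2)c(N[C@@H]2C[C@H](CO)[C@@H](O)[C@H]2O)n1`: > 25000 nM

Both values come from an ADME assay on cells (Homo sapiens) for cytotoxicity, read by polymerase chain reaction, with a stated time of 3 days; a lower number here means that less compound is tolerated, a higher number that more compound is tolerated. For compound 1 the value > 25000 nM is a limit of the assay, not a number. For the measured compounds named here, for compound 2 the value > 25000 nM is likewise a limit, so compound 2 stands at the limit of > 25000 nM in this assay, at which 2 of the 2 values shown sit, and no step between measured compounds can be drawn from these two readings.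

Compound 3, `Cc1nc(Nc2ccccc2)nc(N[C@@H]2C[C@H](CO)[C@@H](O)[C@H]2O)c1-c1nc2ccccc2s1`, is not yet measured. It differs from compound 2 in one place: phenyl in place of propyl on a nitrogen on an aromatic ring.

Going by the values given here, with no measured step to lean on, the expectation rests on compound 2 sitting at the limit of > 25000 nM in this assay, at which 2 of the 2 values shown sit. The step expected is a step that the limit leaves unreadable from compound 2 to compound 3, which is no more than the usual scatter. Compound 3 is therefore expected to give about 30000 nM, in the range 10000 nM to 100000 nM, most likely again reported only as a limit.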

Compound 3, half-maximal cytotoxic concentration: > 25000 nM
Compound 3 was reported as a limit; the forecaster's own chance of this, stated with the estimate: 65%; the middle value does not contradict the limit.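

For the compounds shown here, compound 2 and compound 3 each give only a limit in this assay, so no step between them can be read. The compounds shown leave open at what concentration any of them harms cells, and whether phenyl in place of propyl changes that concentration.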